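This account rests on a few compounds, and the source may have more. Where it says the series, first, only, none or still open, it means among the compounds named here.

Of the compounds shown here, three from one series have been tested, and a fourth has not yet. Compound 1 `Cc1nc(-c2ccccc2F)c(C(=O)N2CCN(c3cc(Cl)cc(Cl)c3)CC2)s1` carries a 3,5-dichlorophenyl on the ring nitrogen of its piperazine; in a functional assay on HL-60 cells (Homo sapiens) for inhibition, read by MTT assay, with a stated time of 72 h (on this read-out higher numbers stand for weaker inhibition and lower numbers for stronger inhibition), compound 1 gives 157 nM. Compound 2 `Cc1nc(-c2cccc(F)c2)c(C(=O)N2CCN(c3cc(Cl)cc(Cl)c3)CC2)o1` has a different core, and the difference between the two cores is not broken down here; in this assay compound 2 gives 41.7 nM. Compound 3 `COc1cc(OC)cc(N2CCN(C(=O)c3oc(C)nc3-c3cccc(F)c3)CC2)c1` keeps the core of compound 2 and differs from it in one place: 3,5-dimethoxyphenyl in place of 3,5-dichlorophenyl on an amine nitrogen in a ring. In this assay compound 3 gives 28.2 nM, so the change produced a 1.5-fold lower number from compound 2 to compound 3 (0.17 log units; within the scatter).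

Compound 4 `COc1cc(OC)cc(N2CCN(C(=O)c3sc(C)nc3-c3ccccc3F)CC2)c1` is built from compound 1 by the same change, (3,5-dimethoxyphenyl in place of 3,5-dichlorophenyl on an amine nitrogen in a ring). Going by the values given here, since the one measured example of this change stayed within the scatter, compound 4 is expected to sit close to compound 1, with an estimated step of a 1.4-fold lower number from compound 1 to compound 4 (0.15 log units; within the scatter) in this assay, because the same change gave a 1.5-fold lower number from compound 2 to compound 3 (0.17 log units; within the scatter). Compound 4 is therefore estimated at 110 nM in this assay, with a likely range from 50 nM to 250 nM.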

Compound 4, half-maximal inhibitory concentration: 96.8 nM
Estimate against measurement, compound 4: 1.1-fold (0.06 log units) above, and the stated range covers the measured number.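

In this assay, putting 3,5-dimethoxyphenyl in place of 3,5-dichlorophenyl gives a 1.6-fold lower number from compound 1 to compound 4 (0.21 log units; within the scatter), a step too small to separate from the differences seen between repeated measurements. Set beside the earlier example, the change looks much the same on both cores: the same change on two cores in this assay, a 1.5-fold lower number (0.17 log units; within the scatter) from compound 2 to compound 3 and a 1.6-fold lower number (0.21 log units; within the scatter) from compound 1 to compound 4, 1.1-fold (0.04 log units) apart, within the scatter of two such steps. This shows that, for these two pairs, carrying the change to a second core left its small size intact, but it does not show that the change truly lowers the number, and two pairs cannot establish that it would behave the same way on any further core.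

The compounds shown leave open whether a group of a different kind on the same ring nitrogen, such as a plain phenyl, an amine-bearing phenyl or a phenyl carrying a carboxylic acid, would produce a step beyond the scatter. They also leave open whether these two small steps would look alike in other cell types.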